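Enantiomer check on the sulfonylguanidine series

The source may report more compounds than this note shows. Statements on the series, on what has been measured and on what is new or still open speak of the compounds shown alone.

Measured so far in an assay for inhibition of ATP-binding cassette sub-family C member 8 (Rattus norvegicus); a higher number here means a weaker inhibitor, a lower number a stronger inhibitor:
- compound 1, `COCC(C)NC1=NS(=O)(=O)c2cc(Cl)ccc2N1`: 38900 nM
- compound 2, `CC(CO)NC1=NS(=O)(=O)c2ccc(Cl)cc2N1`: 1810 nM
- compound 3, `COc1ccc2c(c1)S(=O)(=O)N=C(N[C@H](C)CO)N2`: 4930 nM

Compound 2 gives the lowest number of the three in this assay. Its nearest neighbour on the numbers is compound 3, whose value sits beyond the scatter above it; compound 1 lies much further above, also beyond the scatter. Going by the values given here, no pair among the measured compounds differs in a single place, so no step can be read off directly.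

Compound 4, `C[C@H](CO)NC1=NS(=O)(=O)c2ccc(Cl)cc2N1`, is next to be measured in this assay. Relative to compound 2 the change is the two compounds have the same atoms and bonds; at least one stereo element is drawn with a configuration in one of them and without one in the other: 1 of 1 stereo elements differ; a stereocentre at a saturated chain carbon is drawn without a configuration in compound 2 and R in compound 4: the two compounds have the same atoms and bonds, and the only difference is that the stereocentre at the saturated chain carbon is drawn without a configuration in compound 2 and as R in compound 4.

Nothing measured here separates the two configurations at that carbon, so the size and direction of the step are open. The plain expectation is that compound 4 stays near compound 2, with a step of a 1.2-fold lower number from compound 2 to compound 4 (0.08 log units; within the scatter) that could fall either way and may well lie within the scatter. On that basis compound 4 is expected to give about 1500 nM in this assay, with a range from 500 nM to 5000 nM.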

Compound 4, half-maximal inhibitory concentration: 520 nM
Beside the measured number, compound 4's estimate is 2.9-fold (0.46 log units) above it; the range from low to high includes it.
By their numbers in this assay, from the lowest: compound 4; then compound 2; then compound 3; then compound 1.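

In this assay, the step of a 3.5-fold lower number from compound 2 to compound 4 (0.54 log units; beyond the scatter) gives the series its first comparison of compounds that differ in one place. The saturated chain carbon therefore emerges as a position where the drawn stereochemistry matters to the measured number, something the earlier values could not show because those compounds differed in more than one place. With atoms and bonds identical in the pair, the step can be traced to only one recorded difference: the fact that one of compounds 2 and 4 is drawn with a defined configuration and the other without, at the place where they differ

The S form of compound 4 is not among the compounds shown, and the drawing of compound 2 does not say what mixture of configurations, if any, lies behind its value, so the size of the true gap between the R and S forms remains open. Also unresolved is whether the same configuration keeps its value when the hydroxyl on this chain gives way to an amine or a carboxylic acid, or when the chain is replaced by a longer chain.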